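A methoxybenzyl in place of the difluorobenzyl

The source may report more compounds than this note shows. Statements on the series, on what has been measured and on what is new or still open speak of the compounds shown alone.

Compound 1 `O=C(O)c1ccccc1-c1ccc(CCc2ncc(-c3ccccc3)[nH]2)cc1`: 4950 nM
Compound 2 `O=C(O)c1ccccc1-c1ccc(CCc2ncc(Cc3cccc(F)c3F)[nH]2)cc1`: 87 nM

Both compounds were tested in an in vitro functional assay on cells for agonist activity at Bombesin receptor subtype-3 (Homo sapiens), read by luminescence and calcium flux; on this read-out higher numbers stand for an effect only at larger amounts of compound and lower numbers for an effect already at smaller amounts. Compound 1 gives 4950 nM, while compound 2 gives 87 nM. Among the compounds with values here, the only measured step, a 57-fold lower number from compound 1 to compound 2 (1.76 log units; beyond the scatter), shows that inserting the benzyl carbon and adding the two fluorines moves the number far. Within the data shown here, compound 2 therefore stands at the lower of the two numbers, with compound 1 as its only neighbour.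

Compound 3 `COc1ccccc1Cc1cnc(CCc2ccc(-c3ccccc3C(=O)O)cc2)[nH]1` differs from compound 2 by 2-methoxyphenyl in place of 2,3-difluorophenyl on a saturated chain carbon bound to an aromatic carbon. The step from compound 1 to compound 2 bears on this change only in part: it shows that a benzyl in place of phenyl is what carried the large gain, but nothing measured separates the two fluorines from a methoxy on that benzyl. Compound 3 keeps the benzyl, so the bulk of that gain is expected to remain, and compound 3 is expected to sit at a 2.3-fold higher number from compound 2 to compound 3 (0.36 log units; beyond the scatter), a modest shift likely within the scatter. Compound 3 is thus estimated at 200 nM, within 50 nM to 800 nM.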

Compound 3, half-maximal effective concentration: 1720 nM
Compound 3: middle estimate off by 8.6-fold (0.93 log units), on the low side; measured number outside the range, above it.
By their numbers in this assay, from the lowest: compound 2; then compound 3; then compound 1.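

The swap of 2,3-difluorobenzyl for 2-methoxybenzyl on the saturated chain carbon gives a 20-fold higher number from compound 2 to compound 3 (1.30 log units; beyond the scatter) in this assay, so the benzyl link alone does not secure the large gain seen with compound 2, and what sits on the benzyl ring counts for much of it. Set against the phenyl of the first compound, the 2-methoxybenzyl keeps only a 2.9-fold lower number from compound 1 to compound 3 (0.46 log units; beyond the scatter) as a modest step, which is still beyond the scatter but leaves most of the distance to compound 2 uncovered. Nothing available explains why the two substituted benzyl groups read so differently.

The compounds shown leave open whether the difference comes from the loss of the two fluorines, from the arrival of the methoxy group, or from both, since an unsubstituted benzyl as a reference point lies outside this set. Equally open, from the compounds shown here alone, is whether a single fluorine on the benzyl ring would hold the number of compound 2, and whether a methyl or a chlorine on that ring would read closer to the fluorines or to the methoxy group.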